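This account rests on a few compounds, and the source may have more. Where it says the series, first, only, none or still open, it means among the compounds named here.

Measured compounds:
compound 1 `Brc1ccc(CNc2ccc3ncnc(Nc4cccc(Br)c4)c3c2)cc1` — 2210 nM
compound 2 `Clc1ccccc1CNc1ccc2ncnc(Nc3cccc(Br)c3)c2c1` — 3740 nM
compound 3 `Clc1cccc(Nc2ncnc3ccc(NCc4ccc(Br)cc4)cc23)c1` — 4010 nM

All three numbers come from a functional assay on A16-F10 cells (Homo sapiens) for antiproliferative activity, read by MTT assay, with a stated time of 48 h; a lower number here means a stronger inhibitor, a higher number a weaker inhibitor. Compound 4 `Clc1cccc(Nc2ncnc3ccc(NCc4ccccc4Cl)cc23)c1` has not yet been measured in this assay. It differs from compound 3 by 2-chlorophenyl in place of 4-bromophenyl on a saturated chain carbon bound to a nitrogen on an aromatic ring, and this is the same change as that from compound 1 to compound 2, (2-chlorophenyl in place of 4-bromophenyl on a saturated chain carbon bound to a nitrogen on an aromatic ring), which gave a step of a 1.7-fold higher number from compound 1 to compound 2 (0.23 log units; within the scatter). The cores of the two pairs differ by chloro in place of bromo on an aromatic carbon, a change that gave a 1.8-fold higher number from compound 1 to compound 3 (0.26 log units; within the scatter). Because the measured step of a 1.7-fold higher number from compound 1 to compound 2 (0.23 log units; within the scatter) stayed within the scatter, a step of similar size, a 1.7-fold higher number from compound 3 to compound 4 (0.23 log units; within the scatter), is expected for the new pair. Compound 4 is therefore estimated at 6800 nM, with a plausible range from 3000 nM to 15000 nM.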

Compound 4, half-maximal inhibitory concentration: 7120 nM
Beside the measured number, compound 4's estimate is 1.0-fold (0.02 log units) below it, within the range that was stated.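

In this assay putting 2-chlorophenyl in place of 4-bromophenyl on the core of compound 3 gives a 1.8-fold higher number from compound 3 to compound 4 (0.25 log units; within the scatter) and this agrees with the step on the other core: the same change on two cores in this assay, a 1.7-fold higher number (0.23 log units; within the scatter) from compound 1 to compound 2 and a 1.8-fold higher number (0.25 log units; within the scatter) from compound 3 to compound 4, 1.0-fold (0.02 log units) apart, within the scatter of two such steps. Chloro in place of bromo on an aromatic carbon gives a 1.9-fold higher number from compound 2 to compound 4 (0.28 log units; within the scatter) and this also agrees with its earlier step: the same change on two cores in this assay, a 1.8-fold higher number (0.26 log units; within the scatter) from compound 1 to compound 3 and a 1.9-fold higher number (0.28 log units; within the scatter) from compound 2 to compound 4, 1.0-fold (0.02 log units) apart, within the scatter of two such steps. So each change behaved alike on both cores in these four compounds, but every step lies within the scatter, which means neither change is shown to have a real effect and nothing is shown about other cores.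

The swap alters both the halogen and where it sits, so 4-chlorophenyl or 2-bromophenyl would be needed to separate the two. As far as these compounds go, it also remains open whether the agreement holds for a methoxy group or a carboxylic acid on the phenyl ring, or for a longer chain carrying that ring.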